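Trimming the Amine Substituent on a Cathepsin S Inhibitor

A few compounds are considered here, and "the series" means these few. Any claim that something is new, unique, unknown or untested is made for them only; others in the source may bear on it.

Three cyanopyrrolidine amides form the background here. Compound 1 `N#C[C@@]1(NC(=O)[C@@H](CC(=O)N2CCOCC2)CC2CCC(c3ccccc3)CC2)CCN(C2CCCCC2)C1` carries a cyclohexyl on the ring nitrogen, and in an assay on isolated protein for inhibition of cathepsin S (Homo sapiens) (a lower number here means tighter binding, a higher number weaker binding), compound 1 gives "not determined" (no result reported). Compound 2 `CC(C)N1CC[C@@](C#N)(NC(=O)[C@@H](CC(=O)N2CCOCC2)CC2CCCCC2)C1` bears an isopropyl on that nitrogen, and in this assay compound 2 gives 60.6 nM. Compound 3 `N#C[C@@]1(NC(=O)[C@@H](CC(=O)N2CCOCC2)CC2CCc3ccccc3C2)CCN(C2CCCCC2)C1` differs from compound 2 in several places, and in this assay compound 3 gives 5.4 nM. Of the two numbers that exist, compound 2 stands highest, and its gap to compound 3 lies beyond the usual scatter of repeated measurements.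

The new entry, compound 4 `CN1CC[C@@](C#N)(NC(=O)[C@@H](CC(=O)N2CCOCC2)CC2CCCCC2)C1`, departs from compound 2 in one place only: methyl in place of isopropyl on an amine nitrogen in a ring. For the measured compounds named here, nothing measured so far shows how this assay responds to a smaller group on the amine nitrogen in the ring, so the expectation rests on the structural change alone. Compound 4 is expected to give 100 nM, with a range from 35 nM to 300 nM. The estimated step of a 1.7-fold higher number from compound 2 to compound 4 (0.22 log units; within the scatter) is a modest weakening, though it could fall within scatter.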

Compound 4, dissociation constant: 161 nM
Estimate against measurement, compound 4: 1.6-fold (0.21 log units) below, within the range that was stated.
By their numbers in this assay, from the lowest: compound 3; then compound 2; then compound 4.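

Replacing isopropyl with methyl on the amine nitrogen in the ring, while the rest of the molecule stays the same, gives a 2.7-fold higher number from compound 2 to compound 4 (0.42 log units; beyond the scatter) in this assay. For the compounds shown here, this is the only comparison here that changes a single place, and it shows that binding depends on which group sits on this nitrogen, with the smaller methyl giving the weaker binding of the two. No measurement shown explains the step.

Going by these compounds alone, with only two groups compared directly, it remains open whether an ethyl, a benzyl or a plain hydrogen on this nitrogen would continue the same direction or break from it. Compound 3 carries a cyclohexyl there but also differs in its side chain, so it cannot show what cyclohexyl alone contributes.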